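The compounds below may be only part of what the source reports. "The series", "measured", "known", "first", "only" and "open" are said of these compounds alone.

Compound 1 `C#Cc1cn([C@@H]2O[C@H](CO)[C@@H](O)[C@H]2O)c2ncnc(NC)c12` gives in a functional assay on CCRF-CEM cells (Homo sapiens), read by MTT assay, with a stated time of 72 h (a lower number here means a stronger inhibitor, a higher number a weaker inhibitor), only a limit of the assay, > 20000 nM. Compound 2 `C#Cc1cn([C@@H]2O[C@H](CO)[C@@H](O)[C@H]2O)c2ncnc(OC)c12` likewise reaches only a limit, > 20000 nM. For the measured compounds named here, compound 3 `COc1ncnc2c1c(-c1cc3ccccc3o1)cn2[C@@H]1O[C@H](CO)[C@@H](O)[C@H]1O` gives 5370 nM, the one actual number in the set.

Compound 3 differs from compound 2 by 1-benzofuran-2-yl in place of ethynyl on an aromatic carbon, and this change produces an at least 3.7-fold lower number from compound 2 to compound 3 (0.57 log units; beyond the scatter). Compound 1 differs from compound 2 by methylamino in place of methoxy on an aromatic carbon, but that step is a step that the two limits leave unreadable from compound 2 to compound 1, because the limit of > 20000 nM in this assay, at which 2 of the 3 values shown sit, hides whatever difference exists between them.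

Compound 4 `CNc1ncnc2c1c(-c1cc3ccccc3o1)cn2[C@@H]1O[C@H](CO)[C@@H](O)[C@H]1O` is not yet measured. It differs from compound 3 by methylamino in place of methoxy on an aromatic carbon, the same change as from compound 2 to compound 1. As that earlier step is unreadable, the expectation rests on nothing more than the value of compound 3, so compound 4 is expected to show roughly a 1.1-fold lower number from compound 3 to compound 4 (0.03 log units; within the scatter). Compound 4 is estimated at 5000 nM, with a range from 1500 nM to 20000 nM.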

Compound 4, half-maximal inhibitory concentration: > 20000 nM
Compound 4: a limit, no number; the forecaster's own chance of this, stated with the estimate: 25%; middle value at least 4.0-fold (0.60 log units) away from the limit.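

In this assay, methylamino in place of methoxy on the core carrying 1-benzofuran-2-yl gives an at least 3.7-fold higher number from compound 3 to compound 4 (0.57 log units; beyond the scatter), so on this core the change weakens the compound. This is a single readable case on a single core, and it sets no rule for other cores in the series. Whether the same change acts alike on the core carrying ethynyl cannot be read, nor can the step between compound 1 and compound 4, because each of these steps ends at a limit on both sides: the limit of > 20000 nM in this assay, at which 3 of the 4 values shown sit.

The compounds shown leave open whether an amine or an ethoxy group in place of methoxy would keep the activity of compound 3, at 5370 nM. They also leave open how the methoxy and methylamino groups compare on the core carrying ethynyl.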